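The source may report more compounds than this note shows. Statements on the series, on what has been measured and on what is new or still open speak of the compounds shown alone.

Measured so far in a functional assay on MOLT-4 cells (Homo sapiens) for inhibition, read by sulforhodamine B assay, with a stated time of 48 h; on this read-out higher numbers stand for weaker inhibition of growth and lower numbers for stronger inhibition of growth:
Compound 1 `Cc1ccc(C2=NN(c3ccc(S(C)(=O)=O)cc3)C(=O)CC2)cc1`: > 100000 nM, a limit
Compound 2 `Cc1cc(O)ccc1C1=NN(c2ccc(S(C)(=O)=O)cc2)C(=O)CC1`: > 100000 nM, a limit

Neither entry is a number, since each is a limit of this assay. Within the data shown here, compound 2 therefore has no exact place on the scale, and the one other value beside it is also a limit. The whole record so far is the limit of > 100000 nM in this assay, at which 2 of the 2 values shown sit.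

Compound 3 `CCc1ccc(C2=NN(c3ccc(S(C)(=O)=O)cc3)C(=O)CC2)cc1` differs from compound 2 at a single place: 4-ethylphenyl in place of 4-hydroxy-2-methylphenyl on a carbon with a double bond to nitrogen. Here 4-ethylphenyl takes the place of 4-hydroxy-2-methylphenyl on a carbon with a double bond to nitrogen.

Among the measured compounds shown here, one measured step bears on this change, as it falls at the same place: a step that the two limits leave unreadable from compound 1 to compound 2. It has no readable size, so no measured size can be carried over. With compound 1 and compound 2 both resting at the limit of > 100000 nM in this assay, at which 2 of the 2 values shown sit, no step beyond the scatter is expected in this assay. The expected step is a number no higher from compound 2 to compound 3 (the limit leaves the size open). For compound 3 the estimate is 100000 nM, with an expected range from 40000 nM to 200000 nM. The assay is expected to report most likely only a limit again.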

Compound 3, concentration for total growth inhibition: 6750 nM
Estimate against measurement, compound 3: 15-fold (1.17 log units) above; measured number outside the range, below it.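

At this position, on a carbon with a double bond to nitrogen of the six-membered ring, the choice of aromatic group turns out to matter in this assay: 4-ethylphenyl in place of 4-hydroxy-2-methylphenyl gives an at least 14-fold lower number from compound 2 to compound 3 (1.17 log units; beyond the scatter). The change need not be a large one, since methyl in place of hydrogen on the saturated chain carbon bound to an aromatic carbon, which turns 4-methylphenyl into 4-ethylphenyl, gives an at least 14-fold lower number from compound 1 to compound 3 (1.17 log units; beyond the scatter). The step between the two earlier compounds cannot be read, and compound 3 is the only one of the three with a measured number rather than a limit, so both readable steps start from that limit: the limit of > 100000 nM in this assay, at which 2 of the 3 values shown sit.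

The compounds shown leave open whether a propyl group or a longer chain in place of ethyl would go further along the same direction, and how an amine or a carboxylic acid on the aromatic ring would read. They also leave open which part of compound 2, the hydroxy or the methyl, matters here, since the two groups change together in the step to compound 3.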